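The source may hold more compounds than are shown below. What is called first, only, known or untested is meant among the compounds shown, and "the series" means these compounds.

Working notes on the series. All three measured compounds share one core and differ only in the group on an aromatic carbon of the pendant phenyl: compound 1 `Cn1nc2c(=O)n(CC3(O)CCN(Cc4ccc(-c5ccco5)cc4Cl)CC3)cnc2c1-c1ccc(C(F)(F)F)cc1` carries trifluoromethyl there, and in an assay on isolated protein for inhibition of ubiquitin carboxyl-terminal hydrolase 7 (Homo sapiens), with stated times of 30 min and 2 h (on this read-out higher numbers stand for weaker inhibition and lower numbers for stronger inhibition), compound 1 gives 530 nM. Compound 2 `CC(=O)NCc1ccc(-c2c3ncn(CC4(O)CCN(Cc5ccc(-c6ccco6)cc5Cl)CC4)c(=O)c3nn2C)cc1` carries acetamidomethyl and in this assay compound 2 gives 46.1 nM, a change read as an 11-fold lower number from compound 1 to compound 2 (1.06 log units; beyond the scatter). Compound 3 `Cn1nc2c(=O)n(CC3(O)CCN(Cc4ccc(-c5ccco5)cc4Cl)CC3)cnc2c1-c1ccc(CNC2CC2)cc1` carries (cyclopropylamino)methyl and in this assay compound 3 gives 54.1 nM, the change from the trifluoromethyl parent being a 9.8-fold lower number from compound 1 to compound 3 (0.99 log units; beyond the scatter). Compound 3 therefore sits well apart from compound 1 and alongside compound 2, the pair being separated only by a 1.2-fold higher number from compound 2 to compound 3 (0.07 log units; within the scatter).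

Compound 4 `Cn1nc2c(=O)n(CC3(O)CCN(Cc4ccc(-c5ccco5)cc4Cl)CC3)cnc2c1-c1ccc(CNC=O)cc1` is the next point: formyl in place of cyclopropyl on an amine nitrogen. For the measured compounds named here, the one measured step that bears on this is the exchange on the same amine nitrogen between compound 2 and compound 3, a 1.2-fold higher number from compound 2 to compound 3 (0.07 log units; within the scatter), which stayed within the scatter; compound 2, with acetyl on that nitrogen, is the closest measured relative of compound 4. On that basis no step beyond the scatter is expected, and the estimated move is a 1.1-fold lower number from compound 3 to compound 4 (0.03 log units; within the scatter). Compound 4 is expected to give about 50 nM in this assay, within a range of 25 nM to 110 nM.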

Compound 4, half-maximal inhibitory concentration: 20.9 nM
The estimate for compound 4 lay 2.4-fold (0.38 log units) above the measured number; the whole stated range lies above it.
By their numbers in this assay, from the lowest: compound 4; then compounds 2 and 3 (each within the scatter of the next); then compound 1.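

On this amine nitrogen the group does change the number in this assay: formyl in place of cyclopropyl gives a 2.6-fold lower number from compound 3 to compound 4 (0.41 log units; beyond the scatter), although the acetyl and cyclopropyl of compound 2 and compound 3 had stayed within the scatter of each other. Hydrogen in place of methyl on the carbonyl carbon gives a 2.2-fold lower number from compound 2 to compound 4 (0.34 log units; beyond the scatter), so acetyl and formyl are not interchangeable here, and a carbonyl on this nitrogen does not by itself set the number. Against the trifluoromethyl parent, (formylamino)methyl gives a 25-fold lower number from compound 1 to compound 4 (1.40 log units; beyond the scatter), which places compound 4 lowest of the four, and nothing available accounts for these steps.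

Open, on these data alone, is whether the lower number belongs to formyl alone or extends to other small groups on the same nitrogen, such as the unsubstituted amine, a methanesulfonyl group or a urea. Also open, as far as these compounds go, is whether a methyl group on this nitrogen, with formyl kept in place, would retain the step, and whether the step holds when the rest of the shared core is changed.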